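The compounds below may be only part of what the source reports. "The series", "measured", "known", "first", "only" and "open" are said of these compounds alone.

Measured compounds in an assay on isolated protein (strain Sprague-Dawley) for inhibition of Amine oxidase [flavin-containing] B (Rattus norvegicus), read by spectrophotometry, with a stated time of 5 min; a lower number here means a stronger inhibitor, a higher number a weaker inhibitor:
compound 1 `COCOc1cc(=O)oc2cc(OCc3cccc(Cl)c3)ccc12` — 100 nM
compound 2 `NC(=O)COc1cc(=O)oc2cc(OCc3cccc(Cl)c3)ccc12` — 3.1 nM; 3.31 nM (2 entries)
compound 3 `O=c1cc(Oc2ccccc2)c2ccc(OCc3cccc(Cl)c3)cc2o1` — 4070 nM

Compound 3 has the highest of the two single numbers in this assay; its nearest neighbour is compound 1, and the step of a 41-fold higher number from compound 1 to compound 3 (1.61 log units; beyond the scatter) separates them, where a phenyl replaces a methoxymethyl on an oxygen of the shared core. Compound 2 is reported as several close entries, (the several entries of compound 2 in this assay, 3.1 nM; 3.31 nM (2 entries)), and falls at the low end of the set.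

Compound 4 `O=c1cc(CCl)c2ccc(OCc3cccc(Cl)c3)cc2o1` is not yet measured. It differs from compound 3 in one place: chloromethyl in place of phenoxy on an aromatic carbon. Within the data shown here, no measured step exchanges an oxygen-linked group for a carbon-linked one at this position, so the only guide is the step from compound 1 to compound 3, which shows that a phenyl at this position carries a much higher number than a small group. Removing the phenoxy in favour of chloromethyl is therefore expected to move the number back down, though the change of linking atom leaves the size uncertain. The estimate for compound 4 is 100 nM (range 15 nM to 800 nM), a step of a 41-fold lower number from compound 3 to compound 4 (1.61 log units; beyond the scatter) expected in this assay.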

Compound 4, half-maximal inhibitory concentration: 43.7 nM
Compound 4: middle estimate off by 2.3-fold (0.36 log units), on the high side; low and high end bracket the measured number.
By their numbers in this assay, from the lowest: compound 4; then compound 1; then compound 3.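

In this assay, among these compounds, the position opposite the ring oxygen accepts a carbon-linked group, which the earlier compounds, all oxygen-linked there, could not show: a 93-fold lower number from compound 3 to compound 4 (1.97 log units; beyond the scatter) is larger than the step that first marked phenoxy as unfavourable. Since a 2.3-fold lower number from compound 1 to compound 4 (0.36 log units; beyond the scatter) also favours chloromethyl over methoxymethoxy, losing the oxygen link does not by itself raise the number, and the small chloromethyl gives the lowest number among compound 1, compound 3 and compound 4. Nothing measured here explains either step.

On these data alone, whether the chlorine itself matters stays open, and a plain methyl, an aminomethyl or a longer chain such as propyl at this position would separate it from the carbon link. Also open, as far as these compounds go, is whether an amide on a carbon-linked chain would keep the low numbers of compound 2.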